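Removing a Ring Fluorine in a Glutamate Receptor Modulator Series

The source may report more compounds than this note shows. Statements on the series, on what has been measured and on what is new or still open speak of the compounds shown alone.

Measured compounds:
compound 2 `Cc1c(OCCCCOc2cccc(C(=O)O)c2)ccc(C(=O)CC(C)C)c1O`: 222 nM
compound 3 `Cc1c(OCCCCOc2ccc(F)c(C(=O)O)c2)ccc(C(=O)CC(C)C)c1O`: 153 nM
compound 1 `Cc1c(OCCCCOc2ccc(F)c(C(=O)O)c2)ccc(C(=O)CC2CCCC2)c1C`: "not determined" (no result reported)

In an assay on HEK293 cells for positive allosteric modulation of metabotropic glutamate receptor 2 (Rattus norvegicus), read by thallium flux, with a stated time of 2.5 min (on this read-out higher numbers stand for an effect only at larger amounts of compound and lower numbers for an effect already at smaller amounts), compound 3 gives 153 nM and compound 2 gives 222 nM. The change between them, (hydrogen in place of fluoro on an aromatic carbon), produced a 1.5-fold higher number from compound 3 to compound 2 (0.16 log units; within the scatter). Compound 4 `Cc1c(OCCCCOc2cccc(C(=O)O)c2)ccc(C(=O)CC2CCCC2)c1C` is not yet measured; it arises from compound 1 by the same kind of change, (hydrogen in place of fluoro on an aromatic carbon). The difference between the cores of compound 1 and compound 3 is not broken down here. Within the data shown here, compound 1 has no number in this assay, so no step from compound 1 to compound 4 can be stated; only the step from compound 3 to compound 2, which lies within the scatter, suggests the change itself should move the number little. Compound 2, with 222 nM, is the closest measured compound lacking the fluoro. In this assay compound 4 is therefore expected near 250 nM, within a wide range from 60 nM to 1000 nM.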

Compound 4, half-maximal effective concentration: "not active" (no number reported)
No number was reported for compound 4; the estimate stays without a comparison.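

Among these compounds, neither compound 1 nor compound 4 carries a number, so no step between them can be read. No evidence at hand bears on this result. The compounds shown leave open what removing the fluoro does on the core of compound 1.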